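Lengthening the Amine Chain from Compound 2 to Compound 4

The source may hold more compounds than are shown below. What is called first, only, known or untested is meant among the compounds shown, and "the series" means these compounds.

Of the compounds shown here, three sharing one core have been measured in a physicochemical assay for lipophilicity, using the shake flask method, measured as octanol-water partition, at pH 7.4; a lower number here means a more polar compound, a higher number a more lipophilic compound. Compound 1 `COc1cc(/C=C/C(=O)Nc2ccccc2)ccc1OCCCN1CCCCC1` gives 1.58, compound 2 `COc1cc(/C=C/C(=O)Nc2ccccc2)ccc1OCCCCN(C)C` gives 1.57, and compound 3 `COc1cc(/C=C/C(=O)Nc2ccccc2)ccc1OCCCCCN1CCCC1` gives 1.64. Compound 2 has the lowest of the three numbers, with compound 1 nearest (a number 0.01 log units lower from compound 1 to compound 2 (within the scatter)) and compound 3 furthest (a number 0.07 log units higher from compound 2 to compound 3 (within the scatter)); both gaps lie within the scatter, so the three compounds cannot be told apart.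

Compound 4 `COc1cc(/C=C/C(=O)Nc2ccccc2)ccc1OCCCCCCN1CCCC1` has not yet been measured. It differs from compound 2 in one place: 2-(pyrrolidin-1-yl)ethyl in place of dimethylamino on a saturated chain carbon, four bonds along the chain from an oxygen on an aromatic ring.

For the measured compounds named here, two measured steps bear on this. The step of a number 0.07 log units higher from compound 2 to compound 3 (within the scatter) changes the same position in the same direction, only with a shorter group entering. The step of a number 0.06 log units higher from compound 1 to compound 3 (within the scatter) brings in the very group that enters here, on a neighbouring chain position. Both were within the scatter, so compound 4 is expected to move little beyond compound 2 in this assay, if anything slightly upward, with an estimated step of a number 0.15 log units higher from compound 2 to compound 4 (within the scatter). Compound 4 is therefore estimated at 1.72, within a range from 1.4 to 2.05.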

Compound 4, partition coefficient: 1.76
Beside the measured number, compound 4's estimate is 0.04 log units below it, and the stated range covers the measured number.
By their numbers in this assay, from the lowest: compounds 2, 1, 3 and 4 (each within the scatter of the next).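

In this assay the change at this place, on a saturated chain carbon, four bonds along the chain from an oxygen on an aromatic ring, is now a larger one: dimethylamino, with 3 heavy atoms and no ring, gives way to 2-(pyrrolidin-1-yl)ethyl, with 7 heavy atoms and one five-membered non-aromatic ring, and the result is a number 0.19 log units higher from compound 2 to compound 4 (within the scatter) for this swap. The other two new steps, a number 0.12 log units higher from compound 3 to compound 4 (within the scatter) and a number 0.18 log units higher from compound 1 to compound 4 (within the scatter), tell the same story. Each of these three steps is bigger in size than any step among compounds 1, 2 and 3, yet none of them leaves the scatter, so even this change cannot be told apart from no change at all.

A morpholine or a carboxylic acid in place of dimethylamino would test whether this assay responds at this place to a group of a different kind, and the compounds shown cannot answer that. Nothing shown here offers a measured reason for the size of these steps.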